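The compounds below may be only part of what the source reports. "The series", "measured", "known", "first", "only" and "open" are said of these compounds alone.

Series on the shared core of compound 1 `CCCCCC(=O)Nc1cc2nc(C3CCCCC3)[nH]c2cc1N(CC)CC`; in an ADME assay on Vero cells (Chlorocebus sabaeus) for cytotoxicity, read by resazurin assay, with a stated time of 3 days (on this read-out higher numbers stand for weaker inhibition and lower numbers for stronger inhibition), compound 1 gives "not determined" (no result reported). Within the data shown here, compound 2 `CCCOCC(=O)Nc1cc2nc(C3CCCCC3)[nH]c2cc1N(C)C` is the only entry with a reading there, and in this assay compound 2 gives < 50 ug/mL, a limit of the assay rather than a number, as the limit of < 50 ug/mL in this assay, at which 1 of the 2 values shown sits, records. Compound 3 `CCCCCC(=O)Nc1cc2nc(C3CCCCC3)[nH]c2cc1N(C)C` differs from compound 2 by butyl in place of propoxy on a saturated chain carbon bound to a carbonyl carbon. Among the measured compounds shown here, no measured step of this kind exists, and the single limit offers no direction; the step that the limit leaves unreadable from compound 2 to compound 3 is therefore expected to stay within the scatter. Compound 3 is estimated at 20 ug/mL, between 5 ug/mL and 50 ug/mL.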

Compound 3, half-maximal inhibitory concentration: > 100 ug/mL
Compound 3 ended at the assay's limit; the forecaster's own chance of this, stated with the estimate: 60%; at least 5.0-fold (0.69 log units) between middle value and limit.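

Among these compounds, the only readable step at this position comes from swapping the chain: in this assay, butyl in place of propoxy on a saturated chain carbon bound to a carbonyl carbon gives an at least 2.0-fold higher number from compound 2 to compound 3 (0.30 log units; that floor lies within the scatter). Compound 3 reads > 100 ug/mL, which is a limit of the assay and not a number. The floor of the step stays within the scatter, so the data show no change beyond it.

As far as these compounds go, both ends of the step are limits, and its true size stays open. From the compounds shown here alone, how an amine or a carboxylic acid in this place would read also remains open.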